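The compounds below may be only part of what the source reports. "The series", "measured", "known", "first", "only" and "open" are said of these compounds alone.

Measured in an ADME assay on MT4 cells (Homo sapiens) for cytotoxicity, read by MTT assay, with a stated time of 3 days; a higher number here means that more compound is tolerated, a lower number that less compound is tolerated:
compound 1 `CC(C)(C)N(CCC(=O)c1ccccc1)C(=O)COC(=O)c1ccc([N+](=O)[O-])o1` gives "not active" (no number reported)
compound 2 `CC(=O)Oc1ccccc1CN(C(=O)COC(=O)c1ccc([N+](=O)[O-])o1)C(C)(C)C` gives > 100000 nM
compound 3 `COc1ccc(CN(C(=O)COC(=O)c2ccc([N+](=O)[O-])o2)C(C)(C)C)cc1` gives > 100000 nM

Compound 3 stands at > 100000 nM, which is a limit of the assay and not a number. The series offers only (the limit of > 100000 nM in this assay, at which 2 of the 3 values shown sit), and compound 1 has no number at all. Compound 4 `CC(C)(C)N(Cc1ccc(C(F)(F)F)cc1)C(=O)COC(=O)c1ccc([N+](=O)[O-])o1` carries trifluoromethyl in place of methoxy on an aromatic carbon, para to a large group: trifluoromethyl in place of methoxy on an aromatic carbon. Among the measured compounds shown here, the one measured step, a step that the two limits leave unreadable from compound 2 to compound 3, has no size to carry over, so it indicates no direction in this assay. The expected change is a number no higher from compound 3 to compound 4 (the limit leaves the size open), with nothing beyond the usual scatter foreseen. Compound 4 is estimated at 100000 nM, with an expected range from 40000 nM to 200000 nM.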

Compound 4, half-maximal cytotoxic concentration: 71000 nM
The estimate for compound 4 lay 1.4-fold (0.15 log units) above the measured number; low and high end bracket the measured number.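

With compound 4, the series gains its first actual number in this assay, while the other values shown are limits of the assay or carry no number: the limit of > 100000 nM in this assay, at which 2 of the 4 values shown sit. At this position, trifluoromethyl in place of methoxy gives an at least 1.4-fold lower number from compound 3 to compound 4 (0.14 log units; that floor lies within the scatter), and 4-(trifluoromethyl)phenyl in place of 2-acetoxyphenyl gives an at least 1.4-fold lower number from compound 2 to compound 4 (0.14 log units; that floor lies within the scatter). Both steps are floors set by limits, so neither change is shown to reach beyond the scatter. The compounds shown leave open how an amine or a carboxylic acid at this position would read. As far as these compounds go, the true size of both steps also remains open.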